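Predicting a nitrophenyl urea from a fluoro-chloro forerunner

The source may hold more compounds than are shown below. What is called first, only, known or untested is meant among the compounds shown, and "the series" means these compounds.

Of the compounds shown here, three have been measured in a functional assay for antagonist activity at melanin-concentrating hormone receptor 1 (Homo sapiens); a lower number here means a stronger inhibitor, a higher number a weaker inhibitor. Compound 1 `N#Cc1cccc([C@]23CCC(N(CCN4CC[C@@H](O)C4)C(=O)Nc4cc(F)cc(F)c4)CC2C3)c1` gives 15 nM, and compound 2 `N#Cc1cccc([C@]23CCC(N(CCN4CC[C@@H](O)C4)C(=O)Nc4cccc([N+](=O)[O-])c4)CC2C3)c1` gives 60 nM. Compound 3 `CC(C)N(CCN(C(=O)Nc1ccc(F)c(Cl)c1)C1CC[C@]2(c3cccc(C#N)c3)CC2C1)C(C)C` gives 4.98 nM, the lowest of the three numbers: compound 1 lies nearest, and compound 2 lies furthest, both gaps being beyond the scatter.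

The step under consideration leads from compound 3 to compound 4 `CC(C)N(CCN(C(=O)Nc1cccc([N+](=O)[O-])c1)C1CC[C@]2(c3cccc(C#N)c3)CC2C1)C(C)C`, an unmeasured compound, by the change (3-nitrophenyl in place of 3-chloro-4-fluorophenyl on an amide-type nitrogen). Among the measured compounds shown here, one measured step bears on it: a 4.0-fold higher number from compound 1 to compound 2 (0.60 log units; beyond the scatter). That step replaces a fluorine-bearing phenyl on the urea nitrogen with the same 3-nitrophenyl group that enters here, although the group leaving compound 3 carries a chlorine as well as a fluorine, and the amine side chain of compound 3 differs from that of compound 1. The direction of the step in this assay is therefore expected to be the same, and its size is estimated to be of a similar order.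

Compound 4 is accordingly expected to give 18 nM, with a range from 7 nM to 50 nM, which corresponds to an estimated step of a 3.6-fold higher number from compound 3 to compound 4 (0.56 log units; beyond the scatter).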

Compound 4, inhibition constant: 2.7 nM
For compound 4 the middle estimate is 6.7-fold (0.82 log units) above the measured one, and the stated range ends above it.
By their numbers in this assay, from the lowest: compounds 4 and 3 (each within the scatter of the next); then compound 1; then compound 2.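

In this assay, 3-nitrophenyl in place of 3-chloro-4-fluorophenyl on the amide-type nitrogen, with the diisopropylamino side chain in place, gives a 1.8-fold lower number from compound 3 to compound 4 (0.27 log units; within the scatter), so the two groups cannot be told apart in this setting, whereas the earlier step with the 3-hydroxypyrrolidin-1-yl side chain, a 4.0-fold higher number from compound 1 to compound 2 (0.60 log units; beyond the scatter), lay beyond the scatter. With 3-nitrophenyl held constant, diisopropylamino in place of 3-hydroxypyrrolidin-1-yl gives a 22-fold lower number from compound 2 to compound 4 (1.35 log units; beyond the scatter), so the side chain alone can shift the number far more than either change of aryl group shown here. Nothing available here explains the difference between the two aryl steps.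

The compounds shown leave open whether that difference depends on the side chain or on the halogenated group that leaves, since 3,5-difluorophenyl departs in one step and 3-chloro-4-fluorophenyl in the other, and neither group is shown with the other side chain. Also open, as far as these compounds go, is how a dimethylamino or morpholine group in place of diisopropylamino, or a pyridine ring in place of 3-nitrophenyl, would read in this assay.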